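The compounds below may be only part of what the source reports. "The series", "measured", "known", "first", "only" and "open" are said of these compounds alone.

Measured so far:
compound 1 `Nc1ccc(CNc2cc(Br)cc3[nH]ncc23)cc1`: 3% in an assay for inhibition of Indoleamine 2,3-dioxygenase 1 (Homo sapiens), with a stated time of 1 h, tested at 10 uM; a lower number here means less inhibition, a higher number more inhibition at the concentration tested (going by the name of the read-out)
compound 2 `Brc1cc(NCc2cccs2)c2cn[nH]c2c1`: 54% in this assay

Compound 2 stands highest of the two numbers; compound 1 gives the lower value, and that gap lies beyond the scatter. Among the compounds with values here, no step between measured compounds that differ in one place is available, so the change to compound 3 `Brc1cc(NCc2ccncc2)c2cn[nH]c2c1` is judged from the structures alone: pyridin-4-yl in place of thiophen-2-yl on a saturated chain carbon bound to a nitrogen on an aromatic ring. The expected step is a number 16 percentage points lower from compound 2 to compound 3 (beyond the scatter), a modest move downward in this assay, possibly not beyond the scatter. Compound 3 is thus expected near 38%, between 10% and 65%.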

Compound 3, a percentage reported as inhibition, at one concentration (the size of the read-out at that concentration, not a potency): 54%
Compound 3: middle estimate off by 16 percentage points, on the low side; measured number inside the range.
By their numbers in this assay, from the lowest: compound 1; then compounds 2 and 3 (each within the scatter of the next).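

On the saturated chain carbon bound to a nitrogen on an aromatic ring, pyridin-4-yl in place of thiophen-2-yl gives no change at the digits printed from compound 2 to compound 3 (within the scatter) in this assay. Within the data shown here, this position therefore accepts a six-membered aromatic ring with a ring nitrogen as well as a five-membered one with sulfur, which the earlier compounds could not show. No supporting measurement explains this match.

The compounds shown leave open how phenyl or pyridin-3-yl would read at this place. They also leave open whether a longer chain carrying either ring would hold the read-out.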